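Trimming the Ketone to an Aldehyde

The source may report more compounds than this note shows. Statements on the series, on what has been measured and on what is new or still open speak of the compounds shown alone.

Two measured compounds share one core and were tested in a functional assay (trachea) with Rattus norvegicus as the target; a lower number here means a less potent compound, a higher number a more potent compound, by a factor of ten per unit of this negative logarithm. Compound 1 `COc1ccc(C(=O)c2ccc3c(c2)C(n2ccccc2=O)=CC(C)(C)O3)cc1` gives 5.72. Compound 2 `CC1(C)C=C(n2ccccc2=O)c2cc(C(=O)c3cccs3)ccc2O1` gives 5.84. Going by the values given here, of the two numbers, the one for compound 2 is set down as the higher, yet the step of a number 0.12 log units higher from compound 1 to compound 2 (within the scatter) lies within the scatter, so the two compounds are not told apart by these data. That single step exchanges one group for another on the carbonyl carbon; it never tests what happens when the group is taken away entirely.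

Among the compounds with values here, compound 3 `CC1(C)C=C(n2ccccc2=O)c2cc(C=O)ccc2O1` is the unmeasured one. hydrogen in place of thiophen-2-yl on a carbonyl carbon No measured compound carries only a hydrogen on the carbonyl carbon, so the one step known bears on this change only indirectly. The expectation is a modest fall, estimated as a number 0.44 log units lower from compound 2 to compound 3 (beyond the scatter), resting on compound 2 with its 5.84 as the starting point. Compound 3 is therefore expected to give about 5.4 in this assay, with a range from 4.7 to 6.1.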

Compound 3, logarithm of the reciprocal of the active concentration, log(1/C): 6.14
Estimate against measurement, compound 3: 0.74 log units below; the whole stated range lies below it.
By their numbers in this assay, from the lowest: compounds 1, 2 and 3 (each within the scatter of the next, the first and the last beyond it).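

Taking the ring off the carbonyl carbon altogether does not separate the compounds in this assay: hydrogen in place of thiophen-2-yl gives a number 0.30 log units higher from compound 2 to compound 3 (within the scatter), so compound 2 and compound 3 cannot be told apart by these data. Hydrogen in place of 4-methoxyphenyl gives a number 0.42 log units higher from compound 1 to compound 3 (beyond the scatter), a modest step, and this pair is the only one of the three that lies beyond the scatter. The earlier swap of one ring for another could not show this, but the new compound does: within these three compounds, activity at this level does not depend on an aromatic ring on the carbonyl carbon. Nothing available explains these numbers, so the reason for them remains unknown.

The compounds shown leave open how groups of intermediate size would behave on the carbonyl carbon, such as a methyl or an ethyl group, which would fall between formyl and the ketones carrying a ring. They also leave open whether the carbonyl itself matters, a question that a hydroxymethyl group or a carboxylic acid at the same place could begin to address.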